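This account rests on a few compounds, and the source may have more. Where it says the series, first, only, none or still open, it means among the compounds named here.

Three chalcone-type compounds carry a pyrazole between a substituted phenyl ring and an enone, and all were examined in a functional assay on Malme-3M cells (Homo sapiens) for inhibition, read by sulforhodamine B assay, with a stated time of 48 h; on this read-out higher numbers stand for lower toxicity in this test and lower numbers for higher toxicity in this test. Compound 1 `COc1cc(-c2cc(/C=C/C(=O)c3ccc(N)cc3)[nH]n2)cc(OC)c1OC` gives 14400 nM. Compound 2 `COc1ccc(-c2cc(/C=C/C(=O)c3ccc(N)cc3)[nH]n2)cc1OC` differs from it by hydrogen in place of methoxy on an aromatic carbon, and compound 2 gives 59200 nM. That single change made a step of a 4.1-fold higher number from compound 1 to compound 2 (0.61 log units; beyond the scatter), so removing the methoxy group raised the measured concentration in this assay.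

Compound 3 `COc1cc(C(=O)/C=C/c2cc(-c3cc(OC)c(OC)c(OC)c3)n[nH]2)cc(OC)c1OC` has a different arrangement of the shared parts; how its core differs from the core of compound 1 is not broken down here. In this assay compound 3 gives 8990 nM, which lies close to the value of compound 1, while the value of compound 2 stands well apart from both.

Compound 4 `COc1ccc(-c2cc(/C=C/C(=O)c3cc(OC)c(OC)c(OC)c3)[nH]n2)cc1OC` is not yet measured. It differs from compound 3 by hydrogen in place of methoxy on an aromatic carbon. For the measured compounds named here, this is the same change that separates compound 1 from compound 2, made at a place described in the same words, so the earlier step is the only guide available. On that basis, the step from compound 3 to compound 4 is expected to be about a 3.3-fold higher number from compound 3 to compound 4 (0.52 log units; beyond the scatter), set a little smaller than the measured step because a single precedent such as a 4.1-fold higher number from compound 1 to compound 2 (0.61 log units; beyond the scatter) may overstate what a repeat will show. Compound 4 is therefore estimated to give 30000 nM in this assay, within a range from 12000 nM to 75000 nM.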

Compound 4, concentration lethal to 50% of the cells: 47500 nM
Beside the measured number, compound 4's estimate is 1.6-fold (0.20 log units) below it, and the stated range covers the measured number.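

In this assay the replacement of methoxy by hydrogen on an aromatic carbon gave a 5.3-fold higher number from compound 3 to compound 4 (0.72 log units; beyond the scatter) and so pointed to lower toxicity in this test, the same direction as on the core of compound 1. Set side by side, the two steps agree in size, and in this small set the change carries over from one core to the other with little alteration: the same change on two cores in this assay, a 4.1-fold higher number (0.61 log units; beyond the scatter) from compound 1 to compound 2 and a 5.3-fold higher number (0.72 log units; beyond the scatter) from compound 3 to compound 4, 1.3-fold (0.11 log units) apart, within the scatter of two such steps. For the compounds shown here, this agreement rests on only two matched pairs in a single cell line, so it shows that the step repeated on these two cores, but it does not show that the step would hold on other cores, and it gives no explanation of why the number rises.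

The compounds shown leave open whether the methoxy group itself matters at this place, since only methoxy and hydrogen appear there, and a hydroxyl group, a fluorine atom or a longer chain such as ethoxy would test this more closely. They also leave open whether the size of the step would stay the same in other cell lines or on a core with a different group in place of those carried here.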